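A few compounds are considered here, and "the series" means these few. Any claim that something is new, unique, unknown or untested is made for them only; others in the source may bear on it.

For the measured compounds named here, compound 2 `CC(C)CC(=O)N[C@@H](C(=O)N1CCC(c2ccc(Cl)cc2)CC1)C(C)C` gives 32 nM in an assay on THP-1 cells for displacement of a labelled ligand from C-C chemokine receptor type 1 (Homo sapiens) (a higher number here means a weaker inhibitor, a lower number a stronger inhibitor), the higher of the two numbers so far. Compound 1 `Cc1ccccc1CCC(=O)N[C@@H](C(=O)N1CCC(c2ccc(Cl)cc2)CC1)C(C)C` gives 19 nM in this assay, and the step of a 1.7-fold higher number from compound 1 to compound 2 (0.23 log units; within the scatter) is small. Compound 3 `CC(C)[C@@H](NC(=O)NCc1ccccc1)C(=O)N1CCC(c2ccc(Cl)cc2)CC1` differs from compound 2 by benzylamino in place of isobutyl on a carbonyl carbon. Going by the values given here, the one measured step concerns the saturated chain carbon, not the carbonyl carbon, so nothing directly bears on this change; as that step stayed within the scatter, a step of about a 1.3-fold higher number from compound 2 to compound 3 (0.10 log units; within the scatter) is expected here, with wide uncertainty. Compound 3 is estimated at 40 nM, in the range 12 nM to 130 nM.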

Compound 3, half-maximal inhibitory concentration: 180 nM
Compound 3: middle estimate off by 4.5-fold (0.65 log units), on the low side; measured number above the stated range.
By their numbers in this assay, from the lowest: compounds 1 and 2 (each within the scatter of the next); then compound 3.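

At the carbonyl carbon, benzylamino in place of isobutyl is not a neutral swap in this assay (a 5.6-fold higher number from compound 2 to compound 3 (0.75 log units; beyond the scatter)), unlike the earlier change on the saturated chain carbon. Benzylamino in place of 2-(2-methylphenyl)ethyl at the same carbon also raises the number (a 9.5-fold higher number from compound 1 to compound 3 (0.98 log units; beyond the scatter)), so both carbon-linked groups read better here than benzylamino. Nothing at hand accounts for this loss.

Open, on these data alone, is whether the loss goes with the entering nitrogen or with the aromatic ring. A propylamino group or a plain benzyl group on this carbonyl carbon would separate the two.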